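The source may report more compounds than this note shows. Statements on the series, on what has been measured and on what is new or still open speak of the compounds shown alone.

Compound 1 `CCOC(=O)CCC(=O)N1CCN(CCCOc2cc3c(Nc4ccc(F)c(Cl)c4)ncnc3cc2OC)CC1`: 67.4%
Compound 2 `CCCCCCCCCCCCCOC(=O)CCC(=O)N1CCN(CCCOc2cc3c(Nc4ccc(F)c(Cl)c4)ncnc3cc2OC)CC1`: 71.1%

In a functional assay on A549 cells (Homo sapiens) for cytotoxicity, read by MTT assay, with a stated time of 24 h, tested at 40 uM (on this read-out higher numbers stand for a weaker effect at the one concentration tested and lower numbers for a stronger effect), compound 1 gives 67.4% and compound 2 gives 71.1%. Compound 2 shows the higher of the two numbers, but the step of a number 3.7 percentage points higher from compound 1 to compound 2 (within the scatter) lies within the scatter, so the two compounds cannot be told apart on this read-out. Compound 3 `CCCCCCCCCCCCCCCCCCCOC(=O)CCC(=O)N1CCN(CCCOc2cc3c(Nc4ccc(F)c(Cl)c4)ncnc3cc2OC)CC1` differs from compound 2 by hexyl in place of hydrogen on a saturated chain carbon, ten or more bonds along the chain from an oxygen next to a carbonyl group. Among the measured compounds shown here, the one measured step that bears on this change is a number 3.7 percentage points higher from compound 1 to compound 2 (within the scatter), which lengthened the same chain by a larger group and brought nothing beyond the scatter. A further lengthening of that chain is therefore expected to leave the read-out where compound 2 stands. In this assay the step expected for compound 3 is a number 0.9 percentage points higher from compound 2 to compound 3 (within the scatter), not beyond the scatter. The estimate for compound 3 is 72%, with a range from 58% to 86%.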

Compound 3, a percentage reported as activity, at one concentration (the size of the read-out at that concentration, not a potency): 92.3%
Beside the measured number, compound 3's estimate is 20.3 percentage points below it; the whole stated range lies below it.
By their numbers in this assay, from the lowest: compounds 1 and 2 (each within the scatter of the next); then compound 3.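

In this assay this position is not silent to further lengthening of the chain, since hexyl in place of hydrogen on a saturated chain carbon, ten or more bonds along the chain from an oxygen next to a carbonyl group, gives a number 21.2 percentage points higher from compound 2 to compound 3 (beyond the scatter). That moves the read-out toward a weaker effect at the one concentration tested, whereas the step with the larger group undecyl, a number 3.7 percentage points higher from compound 1 to compound 2 (within the scatter), did not separate its two compounds, so the size of the group added does not alone set the size of the step in these compounds. Nothing available accounts for this change.

The compounds shown leave open where the number begins to rise between compound 2 and compound 3, for instance with propyl in place of hydrogen at this carbon. They also leave open whether an amine or a carboxylic acid at the end of the chain would behave as hexyl does.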